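This account rests on a few compounds, and the source may have more. Where it says the series, first, only, none or still open, it means among the compounds named here.

Measured compounds in a functional assay on MDA-MB-231 cells (Homo sapiens) for cytotoxicity, read by MTT assay, with a stated time of 48 h; a higher number here means a weaker inhibitor, a lower number a stronger inhibitor:
- compound 2 `Cc1ccc(-n2cc(CCCOS(=O)(=O)c3ccc(C)cc3)nn2)cc1`: 36600 nM
- compound 3 `COC(=O)c1ccc(-n2cc(CCCOS(=O)(=O)c3ccc(C)cc3)nn2)cc1`: reported only as a limit, > 100000 nM
- compound 1 `COC(=O)c1ccc(-n2cc(CCCOS(=O)(=O)c3ccc(-c4ccccc4)cc3)nn2)cc1`: "not determined" (no result reported)

Compound 3 therefore stands at the limit of > 100000 nM in this assay, at which 1 of the 3 values shown sits, with no single number of its own. Going by the values given here, the one measured step, an at least 2.7-fold higher number from compound 2 to compound 3 (0.43 log units; beyond the scatter), shows methoxycarbonyl in place of methyl weakening the inhibitor. Compound 4 `Cc1ccc(S(=O)(=O)OCCCc2cn(-c3ccc(C(F)(F)F)cc3)nn2)cc1` differs from compound 3 by trifluoromethyl in place of methoxycarbonyl on an aromatic carbon. Among the compounds with values here, no measured step covers trifluoromethyl, so that step bears on compound 4 only loosely; a return toward the number of compound 2 is possible, but not certain. The step from compound 3 to compound 4 is expected to be an at least 2.0-fold lower number from compound 3 to compound 4 (0.30 log units; that floor lies within the scatter). Compound 4 is estimated at 50000 nM, between 15000 nM and 150000 nM.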

Compound 4, half-maximal inhibitory concentration: > 100000 nM
Compound 4 was reported as a limit (the forecaster's own chance of this, stated with the estimate: 40%); middle value at least 2.0-fold (0.30 log units) from the limit.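

In this assay, trifluoromethyl in place of methyl on this aromatic carbon gives an at least 2.7-fold higher number from compound 2 to compound 4 (0.43 log units; beyond the scatter), so weakening at this position is no longer tied to methoxycarbonyl alone. Methyl is now the only one of the three groups here that gives a single number. Compound 4 is reported only as a limit, and the step between compound 3 and compound 4 cannot be read because both are limits: the limit of > 100000 nM in this assay, at which 2 of the 4 values shown sit.

As far as these compounds go, whether an amine or a carboxylic acid on this carbon would restore a measurable number, or beat methyl, stays open. From the compounds shown here alone, how far compound 3 and compound 4 lie past their limits also stays open.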